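A few compounds are considered here, and "the series" means these few. Any claim that something is new, unique, unknown or untested is made for them only; others in the source may bear on it.

Compound 1 `CCN(C(=O)CC(CC(=O)NCCN1CCCC1)c1ccc(Cl)cc1)C1Cc2ccccc2C1` gives 55500 nM in a functional assay on MGC-803 cells (Homo sapiens) for inhibition; on this read-out higher numbers stand for weaker inhibition and lower numbers for stronger inhibition. Compound 2 `CN(C(=O)CC(CC(=O)NCCN1CCCC1)c1ccc(Cl)cc1)C1Cc2ccccc2C1` carries hydrogen in place of methyl on a saturated chain carbon bound to an amide-type nitrogen and in this assay compound 2 gives 83800 nM, so that a 1.5-fold higher number from compound 1 to compound 2 (0.18 log units; within the scatter). Compound 3 `CCN(CC)CCNC(=O)CC(CC(=O)N(CC)C1Cc2ccccc2C1)c1ccc(Cl)cc1` differs from compound 1 in the core: diethylamino in place of pyrrolidin-1-yl on a saturated chain carbon, two bonds along the chain from an amide-type nitrogen. In this assay compound 3 gives 44900 nM, and a 1.2-fold lower number from compound 1 to compound 3 (0.09 log units; within the scatter). Compound 4 `CCN(CC)CCNC(=O)CC(CC(=O)N(C)C1Cc2ccccc2C1)c1ccc(Cl)cc1` has not been measured; it differs from compound 3 by hydrogen in place of methyl on a saturated chain carbon bound to an amide-type nitrogen, the same change as from compound 1 to compound 2, at the same place in both pairs. Because that change made a 1.5-fold higher number from compound 1 to compound 2 (0.18 log units; within the scatter), a step of similar size is expected here, a 1.4-fold higher number from compound 3 to compound 4 (0.16 log units; within the scatter). The anchor for this is compound 3 at 44900 nM. Compound 4 is therefore estimated at 65000 nM in this assay, expected to fall between 35000 nM and 120000 nM.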

Compound 4, half-maximal inhibitory concentration: 81200 nM
The estimate for compound 4 lay 1.2-fold (0.10 log units) below the measured number, and the stated range covers the measured number.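

Ethyl to methyl gives a 1.8-fold higher number from compound 3 to compound 4 (0.26 log units; within the scatter) in this assay, and this step agrees with the earlier one: the same change on two cores in this assay, a 1.5-fold higher number (0.18 log units; within the scatter) from compound 1 to compound 2 and a 1.8-fold higher number (0.26 log units; within the scatter) from compound 3 to compound 4, 1.2-fold (0.08 log units) apart, within the scatter of two such steps. Diethylamino in place of pyrrolidin-1-yl gives a 1.0-fold lower number from compound 2 to compound 4 (0.01 log units; within the scatter), and this step also agrees with the earlier one: the same change on two cores in this assay, a 1.2-fold lower number (0.09 log units; within the scatter) from compound 1 to compound 3 and a 1.0-fold lower number (0.01 log units; within the scatter) from compound 2 to compound 4, 1.2-fold (0.08 log units) apart, within the scatter of two such steps. All four steps lie within the scatter; this shows that neither change moved the number beyond it on these cores, not that a step of fixed size carries over to other cores.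

Open, going by these compounds, is whether a longer chain such as propyl in place of ethyl, or morpholine or piperidine in place of pyrrolidin-1-yl, would move the number beyond the scatter. On these data alone, the effect of a fluoro or methoxy group in place of the chloro group also remains open.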